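A few compounds are considered here, and "the series" means these few. Any claim that something is new, unique, unknown or untested is made for them only; others in the source may bear on it.

In a functional assay on MV4-11 cells (Homo sapiens) for inhibition, read by luminescence, with a stated time of 72 h (on this read-out higher numbers stand for weaker inhibition and lower numbers for stronger inhibition), compound 1 (`CCN1C(=O)COc2c(CN3CCN(C(C)C)CC3)cc(Nc3ncc(F)c(-c4ccc(F)cc4OC)n3)cc21`) gives 149 nM and compound 2 (`CCN1C(=O)COc2c(CN3CCN(C4COC4)CC3)cc(Nc3ncc(F)c(-c4ccc(F)cc4OC)n3)cc21`) gives 105 nM, so the two stand within the scatter of each other. Compound 3 (`CCN1C(=O)COc2c(CN(C)CCN(C)C)cc(Nc3ncc(F)c(-c4ccc(F)cc4OC)n3)cc21`) carries (2-(dimethylamino)ethyl)(methyl)amino in place of 4-(oxetan-3-yl)piperazin-1-yl on a saturated chain carbon bound to an aromatic carbon. Among the measured compounds shown here, the one measured step, a 1.4-fold lower number from compound 1 to compound 2 (0.15 log units; within the scatter), exchanges only the group on the ring amine nitrogen, and no measured step removes that ring. The expected step, a 1.5-fold higher number from compound 2 to compound 3 (0.18 log units; within the scatter), is small and leans toward a higher number. For compound 3 the estimate is 160 nM, with an expected range of 50 nM to 500 nM.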

Compound 3, half-maximal inhibitory concentration: 143 nM
The estimate for compound 3 lay 1.1-fold (0.05 log units) above the measured number, within the range that was stated.
By their numbers in this assay, from the lowest: compounds 2, 3 and 1 (each within the scatter of the next).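

In this assay, the steps of a 1.4-fold higher number from compound 2 to compound 3 (0.13 log units; within the scatter) and a 1.0-fold lower number from compound 1 to compound 3 (0.02 log units; within the scatter) show that the saturated chain carbon bound to an aromatic carbon can carry (2-(dimethylamino)ethyl)(methyl)amino, which has no ring, in place of either piperazine group without leaving the scatter. Among these compounds, then, the piperazine ring is not required for a number of this size. No evidence bearing on why this holds is available. As far as these compounds go, it remains open whether a morpholine or a carboxylic acid at this place would give a similar number, and whether a longer chain between the two amine nitrogens would do so.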